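A few compounds are considered here, and "the series" means these few. Any claim that something is new, unique, unknown or untested is made for them only; others in the source may bear on it.

Working notes on the series.

Two compounds share one core and differ at a single aromatic carbon. Compound 1 `FC(F)(F)c1cncc(OC[C@@H]2CCN2)c1` carries a trifluoromethyl there and in an assay on brain for binding affinity to Neuronal acetylcholine receptor; alpha4/beta2 (Rattus norvegicus), read by radioligand binding (a lower number here means a stronger inhibitor, a higher number a weaker inhibitor), compound 1 gives 0.49 nM. Among the measured compounds shown here, compound 2 `N#Cc1cncc(OC[C@@H]2CCN2)c1` carries a cyano instead and in this assay compound 2 gives 0.025 nM, the lowest of the two numbers known; the only measured step at this position, a 20-fold lower number from compound 1 to compound 2 (1.29 log units; beyond the scatter), is large and lies beyond the scatter.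

Compound 3 `O=[N+]([O-])c1cncc(OC[C@@H]2CCN2)c1` is the next member: nitro in place of cyano on an aromatic carbon. For the measured compounds named here, the step from compound 1 to compound 2 is the only measured change at the same aromatic carbon and shows that this position tolerates large swings in the number. Going by the values given here, no measured step pairs cyano with nitro, so the direction is not fixed by the data; it is reasonable to expect compound 3 to stay in the low range set by compound 2, with a modest shift either way rather than a step as large as that from compound 1 to compound 2.

On that basis compound 3 is expected to give about 0.06 nM in this assay, within a range of 0.015 nM to 0.3 nM, which corresponds to an expected step of a 2.4-fold higher number from compound 2 to compound 3 (0.38 log units; beyond the scatter).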

Compound 3, inhibition constant: 0.33 nM
For compound 3 the middle estimate is 5.5-fold (0.74 log units) below the measured one; the whole stated range lies below it.
By their numbers in this assay, from the lowest: compound 2; then compounds 3 and 1 (each within the scatter of the next).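

In this assay, the large swing at this aromatic carbon now belongs to the cyano group alone, not to any departure from trifluoromethyl: a 13-fold higher number from compound 2 to compound 3 (1.12 log units; beyond the scatter), so replacing cyano with nitro gives up the low number of compound 2. The other step, a 1.5-fold lower number from compound 1 to compound 3 (0.17 log units; within the scatter), leaves compound 3 and compound 1 within the scatter of each other, so trifluoromethyl and nitro cannot be told apart here, although they differ in name and in their atoms. Across these three compounds, the position therefore shows one outlying group and two that are level, and the change from cyano to nitro proves as large as the change from trifluoromethyl to cyano. Nothing available on these compounds accounts for why the cyano group stands apart.

The compounds shown leave open whether any other group at this carbon, such as an amine, a carboxylic acid, a carboxamide or a chlorine atom, reaches the number of compound 2 or stays with compound 3 and compound 1. They also leave open whether a cyano group keeps this advantage when carried on a longer chain rather than directly on the aromatic carbon.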